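A few compounds are considered here, and "the series" means these few. Any claim that something is new, unique, unknown or untested is made for them only; others in the source may bear on it.

Measured compounds:
compound 1, `CCn1cc(-c2nc3ccccc3[nH]2)c(=O)c2cc(F)c(N3CCNCC3)cc21`, in a functional assay on PC-3 cells (Homo sapiens) for cytotoxicity, read by sulforhodamine B assay, with a stated time of 48 h (on this read-out lower numbers stand for stronger inhibition and higher numbers for weaker inhibition), gives > 10000 nM
compound 2, `CCn1cc(-c2nc3ccccc3[nH]2)c(=O)c2cc(F)c(N3CCNCC3)nc21`, in this assay gives > 10000 nM

In this assay compound 1 reaches only a limit of the assay, > 10000 nM, not a number. Compound 2 likewise reports only a limit, > 10000 nM. Compound 1 thus stands at the limit of > 10000 nM in this assay, at which 2 of the 2 values shown sit, so no ordering between the two can be drawn.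

Compound 3, `CCn1cc(-c2nc3ccc(Cl)cc3[nH]2)c(=O)c2cc(F)c(N3CCNCC3)cc21`, differs from compound 1 by chloro in place of hydrogen on an aromatic carbon. Going by the values given here, no step between measured compounds is known here. In this assay the change is expected to shift the value by no more than the scatter, with a most likely outcome of another limit. Compound 3 is therefore estimated at 12000 nM, with a range of 3000 nM to 40000 nM. The implied step that the limit leaves unreadable from compound 1 to compound 3 is expected to stay within the scatter.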

Compound 3, half-maximal inhibitory concentration: 4800 nM
For compound 3 the middle estimate is 2.5-fold (0.40 log units) above the measured one; measured number inside the range.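

In this assay, replacing 1H-benzimidazol-2-yl with 6-chloro-1H-benzimidazol-2-yl gives an at least 2.0-fold lower number from compound 1 to compound 3 (0.31 log units; beyond the scatter), a change beyond the scatter. Going by these compounds alone, compound 3 is thus the first compound here to give a number rather than a limit, showing that this aromatic carbon can respond to substitution. The full size of the step cannot be read because the value of compound 1 is only a limit: the limit of > 10000 nM in this assay, at which 2 of the 3 values shown sit.

Going by these compounds, whether fluoro, methoxy or an amine on the same carbon would act like chloro remains open. So does whether chloro would lower the number on the core of compound 2.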